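The source may report more compounds than this note shows. Statements on the series, on what has been measured and on what is new or still open speak of the compounds shown alone.

Compound 1 `O=S(=O)(c1ccccc1)c1nc2ccccc2nc1Nc1ccccc1` is the reference point of this small series. In a functional assay on HL-60 cells (Homo sapiens) for cytotoxicity, read by MTT assay, with a stated time of 72 h (a lower number here means a stronger inhibitor, a higher number a weaker inhibitor), compound 1 gives 140 nM. Compound 2 `COc1ccc(Nc2nc3ccccc3nc2S(=O)(=O)c2ccccc2)cc1` carries a single change relative to compound 1, namely (methoxy in place of hydrogen on an aromatic carbon), and in this assay compound 2 gives 640 nM. That change made a 4.6-fold higher number from compound 1 to compound 2 (0.66 log units; beyond the scatter). Compound 3 `COc1cc(Nc2nc3ccccc3nc2S(=O)(=O)c2ccc(F)cc2)cc(OC)c1` rests on a different core; how its core differs from that of compound 1 is not broken down here. In this assay compound 3 gives 2360 nM, the highest number among the three measured compounds. Compound 4 `COc1cc(Nc2nc3ccccc3nc2S(=O)(=O)c2ccc(F)cc2)cc(OC)c1OC` has not yet been measured. It differs from compound 3 by methoxy in place of hydrogen on an aromatic carbon. This is the same kind of change as that from compound 1 to compound 2, but not the same: in compound 4 the entering group sits ortho to two methoxy groups and para to a large group, whereas in compound 2 it sits only para to a large group. Going by the values given here, the only earlier instance of this change is a 4.6-fold higher number from compound 1 to compound 2 (0.66 log units; beyond the scatter). On that basis the expected step is a 2.3-fold higher number from compound 3 to compound 4 (0.37 log units; beyond the scatter), a little smaller than the earlier one. Compound 4 is therefore estimated at 5500 nM, with a likely range from 2200 nM to 14000 nM.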

Compound 4, half-maximal inhibitory concentration: 4790 nM
Compound 4: the middle estimate sits 1.1-fold (0.06 log units) above what was measured, and the stated range covers the measured number.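

In this assay, methoxy in place of hydrogen on an aromatic carbon gave a 2.0-fold higher number from compound 3 to compound 4 (0.31 log units; beyond the scatter), so the number rose with this change on both cores shown. Set beside the earlier step, the two sizes cannot be told apart: the same change on two cores in this assay, a 4.6-fold higher number (0.66 log units; beyond the scatter) from compound 1 to compound 2 and a 2.0-fold higher number (0.31 log units; beyond the scatter) from compound 3 to compound 4, 2.3-fold (0.35 log units) apart, within the scatter of two such steps This supports carrying the direction of the change, and roughly its size, between these two cores, but it rests on only two steps, and it does not show that the step would stay the same on any other core or explain why the number rises.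

Methoxy is the only group entering in these two steps, so it remains open whether a hydroxyl, an amine or a carboxylic acid on the same carbon would shift the number in the same direction. From the compounds shown here alone, it is also open whether a longer chain, such as ethoxy or propoxy, would follow methoxy on either core.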